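Series notes: one ring stereocentre inverted in compound 1

The source may hold more compounds than are shown below. What is called first, only, known or untested is meant among the compounds shown, and "the series" means these compounds.

Measured in a functional assay on B16-F10 cells (Mus musculus) for antiproliferative activity, read by MTT assay, with a stated time of 72 h; on this read-out lower numbers stand for stronger inhibition and higher numbers for weaker inhibition:
- compound 1 `CCCCCCCCNC[C@@H]1OC[C@H](N)[C@@H]1O`: > 128000 nM (a limit of the assay, not a number)
- compound 2 `CCCCCCCCCCCNC[C@@H]1OC[C@H](N)[C@@H]1O`: 19300 nM
- compound 3 `CCCCCCCCCCCCNC[C@@H]1OC[C@H](N)[C@H]1O`: 58100 nM

Compound 1 stands at a limit of the assay, not at a number: the limit of > 128000 nM in this assay, at which 1 of the 3 values shown sits.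

Compound 4 `CCCCCCCCNC[C@@H]1OC[C@H](N)[C@H]1O` is not yet measured. Against compound 1 it shows (the two compounds have the same atoms and bonds and differ only in configuration as drawn: 1 of 3 stereo elements differ; a stereocentre at a saturated ring carbon is drawn S in compound 1 and R in compound 4), so the atoms and bonds are the same and only the configuration as drawn differs.

Going by the values given here, the one measured step, an at least 6.6-fold lower number from compound 1 to compound 2 (0.82 log units; beyond the scatter), lengthens the chain and leaves the configuration alone, so it does not size this change. Compound 3 carries the ring configuration drawn in compound 4, on a longer chain. Compound 3 gives 58100 nM, a higher number than compound 2 at 19300 nM, but that pair differs in chain as well as in configuration.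

Nothing here points to a gain in this assay for the short chain, and no step beyond the scatter is expected: a step that the limit leaves unreadable from compound 1 to compound 4. Compound 4 is estimated at 140000 nM, with an expected range of 70000 nM to 280000 nM, and it may well return only a limit.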

Compound 4, half-maximal inhibitory concentration: > 128000 nM
Compound 4: a limit, no number; the forecaster's own chance of this, stated with the estimate: 65%; the middle value does not contradict the limit.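

In this assay, inverting the ring stereocentre, drawn S in compound 1 and R in compound 4, does not bring the short-chain compound off the limit of the assay, and the step between the two cannot be read: the limit of > 128000 nM in this assay, at which 2 of the 4 values shown sit.

With the R configuration held, chain length can now be read directly: hydrogen in place of butyl on a saturated chain carbon, eight bonds along the chain from an amine nitrogen, gives an at least 2.2-fold higher number from compound 3 to compound 4 (0.34 log units; beyond the scatter). The S configuration gives an at least 6.6-fold lower number from compound 1 to compound 2 (0.82 log units; beyond the scatter), so in both pairs the longer chain carries the lower number, and the chain effect is no longer seen in one configuration only.

As far as these compounds go, the size of the effect of inversion stays open, as the short-chain pair gives only limits and compound 2 and compound 3 differ in chain as well as configuration. A longer chain than that of compound 3, carried in both ring configurations, could give a pair with a number on each side and so size the inversion.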